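Trifluoromethyl for Methyl in a Series at the Assay Limit

The source may hold more compounds than are shown below. What is called first, only, known or untested is meant among the compounds shown, and "the series" means these compounds.

Compound 1 `C/C(=C\c1cc(-c2ccc(F)nc2)co1)C(N)=O` in a functional assay on A549 cells (Homo sapiens) for cytotoxicity, read by CCK-8 assay, with a stated time of 24 h (on this read-out lower numbers stand for stronger inhibition and higher numbers for weaker inhibition), gives > 50000 nM, a limit of the assay.
Compound 2 `C/C(=C\c1cc(-c2ccc(C)cc2)cs1)C(N)=O` in this assay gives > 50000 nM, also a limit.
Compound 3 `C/C(=C\c1cc(-c2ccccc2C)cs1)C(N)=O` in this assay gives > 50000 nM, again a limit.

Compound 2 therefore stands where every value shown stands, at the limit of > 50000 nM in this assay, at which 3 of the 3 values shown sit; no number separates it from compound 1 or compound 3. Compound 4 `C/C(=C\c1cc(-c2ccc(C(F)(F)F)cc2)cs1)C(N)=O` differs from compound 2 by trifluoromethyl in place of methyl on an aromatic carbon. Among the measured compounds shown here, no measured step is available for guidance, so the expectation for this assay is no change beyond the scatter, and compound 4 is expected to remain at the limit, with the step that the limit leaves unreadable from compound 2 to compound 4 estimated as flat. Compound 4 is estimated at 60000 nM, within 20000 nM to 200000 nM.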

Compound 4, half-maximal inhibitory concentration: > 50000 nM
Compound 4: a limit, no number (the forecaster's own chance of this, stated with the estimate: 80%); the middle value does not contradict the limit.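

The step from compound 2 to compound 4 cannot be read, because both compounds give a limit rather than a number: the limit of > 50000 nM in this assay, at which 4 of the 4 values shown sit. The compounds shown leave open whether any change to the shared core would give a number in this assay at all.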